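The source may hold more compounds than are shown below. What is called first, only, known or untested is meant among the compounds shown, and "the series" means these compounds.

Measured so far in a functional assay on HUVEC cells (Homo sapiens), read by BrdU incorporation, with a stated time of 72 h; on this read-out higher numbers stand for weaker inhibition and lower numbers for stronger inhibition
- Compound 1 `Cc1ccc2nc(Cl)c(/C=C/C(=O)c3ccc(Cl)s3)cc2c1` gives 59.4 nM
- Compound 2 `Cc1ccc2cc(/C=C/C(=O)c3ccc(Br)s3)c(Cl)nc2c1` gives 83.6 nM
- Compound 3 `Cc1ccc2nc(Cl)c(/C=C/C(=O)c3cc(Cl)sc3Cl)cc2c1` gives 26.2 nM

Compound 3 has the lowest number of the three. Compound 4 `Cc1ccc2nc(Cl)c(/C=C/C(=O)c3sccc3Br)cc2c1` carries 3-bromothiophen-2-yl in place of 2,5-dichlorothiophen-3-yl on a carbonyl carbon. Within the data shown here, the one measured step bearing on this is modest: a 2.3-fold lower number from compound 1 to compound 3 (0.36 log units; beyond the scatter), on going from 5-chlorothiophen-2-yl to 2,5-dichlorothiophen-3-yl. Among the measured compounds shown here, compound 4 returns to a thiophen-2-yl group, as in compound 1 , although its bromine placement has no measured counterpart. A modest step to a higher number is therefore expected in this assay. The expected change is a 2.3-fold higher number from compound 3 to compound 4 (0.36 log units; beyond the scatter). For compound 4 the estimated value is 60 nM, with an expected range of 22 nM to 165 nM.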

Compound 4, half-maximal inhibitory concentration: 61.9 nM
Compound 4: the middle estimate sits 1.0-fold (0.01 log units) below what was measured; low and high end bracket the measured number.
By their numbers in this assay, from the lowest: compound 3; then compounds 1, 4 and 2 (each within the scatter of the next).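

In this assay, the group on the carbonyl carbon shows a second thiophene with a higher number than compound 3 (a 2.4-fold higher number from compound 3 to compound 4 (0.37 log units; beyond the scatter)), so the lower number of compound 3 does not extend to 3-bromothiophen-2-yl. Changing 5-chlorothiophen-2-yl to 3-bromothiophen-2-yl leaves the read-out within the scatter (a 1.0-fold higher number from compound 1 to compound 4 (0.02 log units; within the scatter)), so this change of halogen and its placement gives no separation here. No available data explain either step. Still open, on these data alone, is whether the lower number of compound 3 goes with its two chlorines or with its thiophen-3-yl linkage. As far as these compounds go, how an amine or a carboxylic acid on the thiophene would read also remains open.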